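From amino to hydroxy in one small step

The source may report more compounds than this note shows. Statements on the series, on what has been measured and on what is new or still open speak of the compounds shown alone.

Compound 1 `Cc1cn([C@@H]2O[C@H](CO)[C@@H](CO)[C@@H]2O)c(=O)[nH]c1=O` and compound 2 `Cc1cn([C@H]2C[C@H](CN)[C@@H](CO)O2)c(=O)[nH]c1=O` have both been tested. In a functional assay on CCRF-CEM cells (Homo sapiens) for antiproliferative activity, with a stated time of 72 h (a lower number here means that less compound is needed, a higher number that more compound is needed for the effect), compound 1 gives > 100 uM as a limit and not a number. Compound 2 gives > 100 uM as a limit too, so it stands at the limit of > 100 uM in this assay, at which 2 of the 2 values shown sit, with no exact figure. Among the measured compounds shown here, compound 3 `Cc1cn([C@H]2C[C@H](CO)[C@@H](CO)O2)c(=O)[nH]c1=O` has hydroxy in place of amino on a saturated chain carbon bound to a saturated ring carbon as its only difference from compound 2. For the measured compounds named here, no measured pair shows this swap, so in this assay no step beyond the scatter is expected. The estimated change is a step that the limit leaves unreadable from compound 2 to compound 3 and no more. For compound 3 the estimate is 150 uM with an expected range of 60 uM to 300 uM in this assay.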

Compound 3, concentration for half-maximal effect: 1 uM
Compound 3: the middle estimate sits 150-fold (2.18 log units) above what was measured, outside the stated range (below it).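

In this assay, hydroxy in place of amino on a saturated chain carbon bound to a saturated ring carbon brings an at least 100-fold lower number from compound 2 to compound 3 (2.00 log units; beyond the scatter), so this single atom separates a clear effect from none that could be put into a number. Hydrogen in place of hydroxy on a saturated ring carbon brings an at least 100-fold lower number from compound 1 to compound 3 (2.00 log units; beyond the scatter), so a second place in the molecule matters too. Both steps give only a minimum size, as the starting compounds have no exact figure: the limit of > 100 uM in this assay, at which 2 of the 3 values shown sit.

From the compounds shown here alone, whether a methoxy group or a longer chain such as hydroxyethyl would keep the effect stays open. So does what a fluorine atom would do on that saturated ring carbon.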